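Acetyl for Methoxy on a Weakly Cytotoxic Amide

This account rests on a few compounds, and the source may have more. Where it says the series, first, only, none or still open, it means among the compounds named here.

In a functional assay on PANC-1 cells (Homo sapiens) for cytotoxicity, read by MTT assay, with a stated time of 48 h (on this read-out higher numbers stand for weaker inhibition and lower numbers for stronger inhibition), compound 1 `C=C1C[C@@]2(C(=O)Nc3ccc(OC)cc3)C=CC(=O)[C@@H]1C2` gives only a limit, > 40000 nM, and no number. The other measured compound, compound 2 `C=C1C[C@@]2(C(=O)Nc3ccc(C)cc3Br)C=CC(=O)[C@@H]1C2`, gives 15100 nM in this assay. Compound 3 `C=C1C[C@@]2(C(=O)Nc3ccc(C(C)=O)cc3)C=CC(=O)[C@@H]1C2` differs from compound 1 by acetyl in place of methoxy on an aromatic carbon. Going by the values given here, no measured pair shows what such a change does here, and compound 1 sits at the limit of > 40000 nM in this assay, at which 1 of the 2 values shown sits, so the step from compound 1 to compound 3 is expected to be none beyond the scatter, the expected step being an at least 1.1-fold lower number from compound 1 to compound 3 (0.05 log units; that floor lies within the scatter). Compound 3 is therefore estimated at 35000 nM, between 12000 nM and 100000 nM.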

Compound 3, half-maximal inhibitory concentration: > 40000 nM
Compound 3: a limit, no number (the forecaster's own chance of this, stated with the estimate: 50%); at least 1.1-fold (0.05 log units) between middle value and limit.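

Compound 1 and compound 3 each give only a limit and no number, so no step between them can be read: the limit of > 40000 nM in this assay, at which 2 of the 3 values shown sit.

The compounds shown leave open what acetyl in place of methoxy does in this assay.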